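The compounds below may be only part of what the source reports. "The series", "measured", "known", "first", "only" and "open" are said of these compounds alone.

Compound 3 `COc1cccc(CNCCCNc2ccnc3cc(Cc4cccc(C(F)(F)F)c4)ccc23)c1O` gives 1720 nM in an ADME assay on HepG2 cells (Homo sapiens) for cytotoxicity, read by luminescence, CellTiter-Glo and ATP content, with a stated time of 72 h (on this read-out higher numbers stand for an effect only at larger amounts of compound and lower numbers for an effect already at smaller amounts), the highest of the three numbers recorded. Compound 1 `COc1cccc(CNCCCNc2ccnc3cc(C4CCCCC4)ccc23)c1O` gives 1080 nM and compound 2 `COc1cccc(CNCCCNc2ccnc3cc(-c4ccc(C(C)(C)C)cc4)ccc23)c1O` gives 690 nM. The step of a 1.6-fold higher number from compound 1 to compound 3 (0.20 log units; within the scatter) lies within the scatter, whereas a 2.5-fold higher number from compound 2 to compound 3 (0.40 log units; beyond the scatter) is modest but beyond it. Compound 4 `COc1ccccc1Oc1ccc2c(NCCCNCc3cccc(OC)c3O)ccnc2c1` differs from compound 3 by 2-methoxyphenoxy in place of 3-(trifluoromethyl)benzyl on an aromatic carbon. Among the compounds with values here, no measured step exchanges a benzyl group for a phenoxy group, so the earlier steps bear on this change only loosely; swapping one substituent for another on the same aromatic carbon has so far shifted the number by no more than a modest amount. On that basis the estimated step is a 1.3-fold lower number from compound 3 to compound 4 (0.12 log units; within the scatter). Compound 4 is expected to give 1300 nM in this assay, with a range from 500 nM to 3500 nM.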

Compound 4, half-maximal effective concentration: 11200 nM
Compound 4: middle estimate off by 8.6-fold (0.94 log units), on the low side; measured number above the stated range.
By their numbers in this assay, from the lowest: compounds 2, 1 and 3 (each within the scatter of the next, the first and the last beyond it); then compound 4.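

In this assay 2-methoxyphenoxy stands apart from all three earlier groups on this aromatic carbon, with a 6.5-fold higher number from compound 3 to compound 4 (0.81 log units; beyond the scatter) and a 10-fold higher number from compound 1 to compound 4 (1.02 log units; beyond the scatter) and a 16-fold higher number from compound 2 to compound 4 (1.21 log units; beyond the scatter) as the steps to it. Exchanges among cyclohexyl, 4-(tert-butyl)phenyl and 3-(trifluoromethyl)benzyl had shown at most a modest shift, so this position allows much larger changes than they revealed. Nothing available explains this shift. Still open, going by these compounds, is whether it follows the ring-linking oxygen or the methoxy group; unsubstituted phenoxy and 2-methoxybenzyl would separate the two.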